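A few compounds are considered here, and "the series" means these few. Any claim that something is new, unique, unknown or untested is made for them only; others in the source may bear on it.

Within the data shown here, in an ADME assay on the whole organism (Rattus norvegicus, strain Wistar Han) for pharmacokinetics, read by LC-MS, with a stated time of 7 h, at a dose of 1 mg/kg by the intravenous route (a lower number here means slower removal, a higher number faster removal of the compound), compound 1 (`CNC(=O)c1cc(C(=O)N[C@H]2[C@@H]3COC[C@@H]32)cc2c1OC[C@@]2(C)c1ccccc1`) gives 274 mL/min/kg, the lower of the two numbers so far. Compound 2 (`CNC(=O)c1cc(C(=O)NC2CC2)cc2c1OC[C@H]2c1ccccc1`) gives 723 mL/min/kg, and this gap lies beyond the usual scatter. Compound 3 (`CNC(=O)c1cc(C(=O)N[C@H]2[C@@H]3C[C@@H](O)C[C@@H]32)cc2c1OC[C@@]2(C)c1ccccc1`) keeps the core of compound 1 and changes only the group on an amide-type nitrogen: a group of 7 heavy atoms (6 carbon, 1 oxygen; one three-membered non-aromatic ring of carbon only, one five-membered non-aromatic ring of carbon only) in place of a group of 6 heavy atoms (5 carbon, 1 oxygen; one three-membered non-aromatic ring of carbon only, one five-membered non-aromatic ring with 1 hetero atom), on an amide-type nitrogen. Among the measured compounds shown here, no measured pair shows this swap, so the data offer no direct guide. The estimated step of a 1.1-fold lower number from compound 1 to compound 3 (0.04 log units; within the scatter) is expected to stay within the scatter, with no clear direction. For compound 3 the expected clearance is 250 mL/min/kg, with an estimated range of 120 mL/min/kg to 520 mL/min/kg.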

Compound 3, clearance in the Rattus norvegicus assay: 260 mL/min/kg
Compound 3: the middle estimate sits 1.0-fold (0.02 log units) below what was measured; measured number inside the range.
By their numbers in the Rattus norvegicus assay, from the lowest: compounds 3 and 1 (each within the scatter of the next); then compound 2.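

On the amide-type nitrogen, the group with a five-membered ring of carbon only and a hydrogen-bond donor takes the place of the group in compound 1, and in the Rattus norvegicus assay this gives a 1.1-fold lower number from compound 1 to compound 3 (0.02 log units; within the scatter) and so leaves the rate of removal unmoved. The same swap does move lipophilicity, so here the two read-outs part ways in a physicochemical assay for lipophilicity, at pH 7.4; on this read-out higher numbers stand for higher lipophilicity and lower numbers for lower lipophilicity: the measured distribution coefficient of compound 1, 3.7, and of compound 3, 3.3, a number 0.40 log units lower (beyond the scatter). In the physicochemical assay compound 1 gives 3.7 and compound 3 gives 3.3.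

From the compounds shown here alone, whether an amine or a carboxylic acid on this nitrogen would shift clearance stays open. So does whether a longer chain carrying the hydroxyl would behave like compound 3.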